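The source may hold more compounds than are shown below. What is called first, only, known or untested is meant among the compounds shown, and "the series" means these compounds.

Measured so far:
Compound 1, `COc1ccc(C(=O)/C(=C/c2ccc(Cl)cc2Cl)CC(C)OC(C)=O)cc1`, gives 36800 nM in a functional assay on NB-4 cells (Homo sapiens) for inhibition, read by XTT assay, with a stated time of 48 h; a lower number here means a stronger inhibitor, a higher number a weaker inhibitor.
Compound 2, `COc1ccc(C(=O)/C(=C/c2ccc(Cl)cc2Cl)CC2CCCCC2)cc1`, gives 48900 nM in this assay.

In this assay the two numbers sit within the scatter of each other, the step of a 1.3-fold higher number from compound 1 to compound 2 (0.12 log units; within the scatter) showing as much, so compound 2 cannot be set apart from compound 1. Compound 3, `COc1ccc(C(=O)/C(=C/c2ccc(Cl)cc2Cl)CN(C)C(=O)c2ccccc2)cc1`, differs from compound 2 by benzoyl(methyl)amino in place of cyclohexyl on a saturated chain carbon bound to a double-bonded chain carbon. Within the data shown here, the only measured step at this position, a 1.3-fold higher number from compound 1 to compound 2 (0.12 log units; within the scatter), stayed within the scatter, and no other step bears on the change, so for compound 3 no step beyond the scatter is expected in this assay, the expected step being a 1.2-fold lower number from compound 2 to compound 3 (0.09 log units; within the scatter). Compound 3 is estimated to give 40000 nM, with a range from 14000 nM to 110000 nM.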

Compound 3, half-maximal inhibitory concentration: 24000 nM
Compound 3: middle estimate off by 1.7-fold (0.22 log units), on the high side, within the range that was stated.
By their numbers in this assay, from the lowest: compounds 3, 1 and 2 (each within the scatter of the next, the first and the last beyond it).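

In this assay, the position on a saturated chain carbon bound to a double-bonded chain carbon shows its first step beyond the scatter, a modest one, when benzoyl(methyl)amino replaces cyclohexyl (a 2.0-fold lower number from compound 2 to compound 3 (0.31 log units; beyond the scatter)). Set against 1-acetoxyethyl, the same group stays within the scatter (a 1.5-fold lower number from compound 1 to compound 3 (0.19 log units; within the scatter)), so only compound 2 and compound 3 can be told apart. No evidence at hand bears on this result. The compounds shown leave open how a plain dimethylamino group or a carboxylic acid at this position would read.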